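Swapping fluoro for chloro on the shared core

This account rests on a few compounds, and the source may have more. Where it says the series, first, only, none or still open, it means among the compounds named here.

Compound 2 `Fc1ccc(-c2cn3ccnc3c(-c3ccc4ncn(C5CCCCC5)c4c3)n2)cc1` is tested in a functional assay on SK-MEL-28 cells (Homo sapiens) for inhibition, read by sulforhodamine B assay, with a stated time of 48 h, tested at 10 uM (a lower number here means less inhibition, a higher number more inhibition at the concentration tested (going by the name of the read-out)), where compound 2 gives 2.67%. That is the lowest of the two numbers measured: compound 1 `COc1ccc(-c2cn3ccnc3c(-c3ccc4ncn(C5CCCCC5)c4c3)n2)cc1` gives 47.7%, and the step of a number 45 percentage points lower from compound 1 to compound 2 (beyond the scatter) is a fluoro in place of methoxy on an aromatic carbon. Compound 3 `Clc1ccc(-c2cn3ccnc3c(-c3ccc4ncn(C5CCCCC5)c4c3)n2)cc1` has not yet been measured. It differs from compound 2 by chloro in place of fluoro on an aromatic carbon, at a place para to a large group on the six-membered aromatic ring of carbon only. Among the compounds with values here, no measured step swaps fluoro for chloro, so the only guide is that compound 2, with fluoro, gives 2.67% and sits far below compound 1. Without a step that bears directly on this change, the expected step is small, a number 7.3 percentage points higher from compound 2 to compound 3 (within the scatter), probably within the scatter. Compound 3 is therefore expected to give 10%, in a range from 0% to 40%.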

Compound 3, a percentage reported as inhibition, at one concentration (the size of the read-out at that concentration, not a potency): 12.1%
Compound 3: the middle estimate sits 2.1 percentage points below what was measured; measured number inside the range.
By their numbers in this assay, from the lowest: compounds 2 and 3 (each within the scatter of the next); then compound 1.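

In this assay the change from 4-fluorophenyl to 4-chlorophenyl gives a number 9.4 percentage points higher from compound 2 to compound 3 (within the scatter) and so, at this place para to a large group, these two halogens cannot be told apart. Putting chloro in place of methoxy gives a number 35.6 percentage points lower from compound 1 to compound 3 (beyond the scatter) and this matches the large drop already seen with fluoro, so the gap to methoxy now holds for both halogens. No measurement available here explains why methoxy stands apart from fluoro and chloro.

From the compounds shown here alone, it remains open whether the higher number belongs to methoxy alone or would also appear with another group at this place, such as an ethoxy group, a hydroxyl or an amine. A larger halogen such as bromo, or methoxy moved elsewhere on the ring, is also untested in the compounds shown.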